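The source may report more compounds than this note shows. Statements on the series, on what has been measured and on what is new or still open speak of the compounds shown alone.

Measured so far:
Compound 1 `CC(C)c1noc(N2CCC(Oc3cc(N4CCc5cc(C6CCCCC6=O)ccc54)ncn3)CC2)n1` — 48 nM
Compound 2 `CC(C)SC(=O)N1CCC(Oc2cc(N3CCc4ccccc43)ncn2)CC1` — > 10000 nM

Of the compounds shown here, two have been tested in an assay on CHO cells for agonist activity at Glucose-dependent insulinotropic receptor (Homo sapiens), read by a luciferase reporter and cAMP accumulation, with a stated time of 2 h; on this read-out higher numbers stand for an effect only at larger amounts of compound and lower numbers for an effect already at smaller amounts. Within the data shown here, compound 1 gives 48 nM, and this is the only actual number in the set. For compound 2 the result is a limit rather than a number: it reads > 10000 nM, meaning no effect was seen up to the top amount tested (the limit of > 10000 nM in this assay, at which 1 of the 2 values shown sits). Among the measured compounds shown here, compound 2 also differs from compound 1 in more than one place, so no single step between them can be read off. Compound 1 therefore stands alone as the one reference point with a measured value.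

The next compound, compound 3 `CC(C)c1noc(N2CCC(Oc3cc(N4CCc5cc(S(=O)(=O)CCO)ccc54)ncn3)CC2)n1`, keeps the whole core of compound 1 and changes one group: (2-hydroxyethyl)sulfonyl in place of 2-oxocyclohexyl on an aromatic carbon. For the measured compounds named here, no measured step of this kind is available to guide the expectation. A small group of moderate polarity is swapped for another small group with a hydroxyl, and the step from compound 1 to compound 3 in this assay is expected to be a mild loss, a 2.5-fold higher number from compound 1 to compound 3 (0.40 log units; beyond the scatter), possibly no more than the scatter. Compound 3 is therefore estimated at 120 nM, within a range of 30 nM to 500 nM.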

Compound 3, half-maximal effective concentration: 41 nM
Estimate against measurement, compound 3: 2.9-fold (0.47 log units) above, and the stated range covers the measured number.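

At this aromatic carbon, (2-hydroxyethyl)sulfonyl in place of 2-oxocyclohexyl gives a 1.2-fold lower number from compound 1 to compound 3 (0.07 log units; within the scatter) in this assay, so the two groups cannot be told apart on this read-out. Among these compounds, this is the first measured step at this position, and it shows that two very different groups can sit there with no change beyond the scatter: one is a six-membered ring of carbon with no hydrogen-bond donor, and the other is an open chain with a sulfur, a hydrogen-bond donor and more hydrogen-bond acceptors. Nothing measured here explains why the two groups give such similar numbers.

Compound 2, with > 10000 nM, carries a limit of the assay rather than a number and differs from compound 1 in more than one place, so it cannot show how much the group at this carbon matters. As far as these compounds go, how an amine, a carboxylic acid or a longer carbon chain would behave at this carbon remains open, as does whether the tolerance seen here extends beyond these two groups.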